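Chloro for fluoro: a small swap on compound 2

A few compounds are considered here, and "the series" means these few. Any claim that something is new, unique, unknown or untested is made for them only; others in the source may bear on it.

Compound 1 `CC(=O)N[C@@H]1CCC[C@H](C(=O)Nc2cc(-c3cnc4n3CCCC4)c(Cl)cn2)C1` gives 16 mL.min-1.g-1
Compound 2 `CC(=O)N[C@@H]1CCC[C@H](C(=O)Nc2cc(-c3cnn4c3CC(C)(C)C4)c(F)cn2)C1` gives 19 mL.min-1.g-1

In an ADME assay on microsomes from liver (Homo sapiens) for metabolic stability (on this read-out higher numbers stand for fast clearance and lower numbers for slow clearance), compound 2 stands within the usual scatter of compound 1, so these two numbers cannot be told apart. Compound 3 `CC(=O)N[C@@H]1CCC[C@H](C(=O)Nc2cc(-c3cnn4c3CC(C)(C)C4)c(Cl)cn2)C1` has chloro in place of fluoro on an aromatic carbon. Among the measured compounds shown here, no measured pair shows this swap alone, so there is no direct guide to its size. A step beyond the scatter is not expected, and the estimated step of a 1.2-fold higher number from compound 2 to compound 3 (0.06 log units; within the scatter) stays small. The expected value for compound 3 is 22 mL.min-1.g-1 (estimated range 11 mL.min-1.g-1 to 42 mL.min-1.g-1).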

Compound 3, intrinsic clearance in microsomes: 50 mL.min-1.g-1
For compound 3 the middle estimate is 2.3-fold (0.36 log units) below the measured one, outside the stated range (above it).
By their numbers in this assay, from the lowest: compounds 1 and 2 (each within the scatter of the next); then compound 3.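

In this assay, this position on the six-membered aromatic ring proves sensitive to a single atom: chloro in place of fluoro gives a step beyond the scatter (a 2.6-fold higher number from compound 2 to compound 3 (0.42 log units; beyond the scatter)). With chloro held constant, changing the other ring group also moves the number beyond the scatter (a 3.1-fold higher number from compound 1 to compound 3 (0.49 log units; beyond the scatter)). Nothing shown here gives a reason for either step. Still open, from the compounds shown here alone, is where a methyl or a nitrile at this position would fall, and whether the same swap would give a similar step on the core of compound 1.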